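Azetidine amide series: fluoro for chloro on the aryl ring

A few compounds are considered here, and "the series" means these few. Any claim that something is new, unique, unknown or untested is made for them only; others in the source may bear on it.

Measured so far in an assay on HEK293 cells for positive allosteric modulation of metabotropic glutamate receptor 5 (Homo sapiens), read by FLIPR; a higher number here means that more compound is needed for the effect, a lower number that less compound is needed:
compound 1 `O=C(c1cccc(F)c1)N1CC(c2nc(-c3cccc(Cl)c3)no2)C1` — > 10000 nM, a limit of the assay, not a number
compound 2 `O=C(c1ccc(F)cc1)N1CC(c2nc(-c3cccc(F)c3)no2)C1` — 2400 nM
compound 3 `O=C([C@@H]1CC2CCC1C2)N1CC(c2nc(-c3cccc(Cl)c3)no2)C1` — 98 nM

Compound 3 holds the lowest of the two numbers shown; compound 2 is the nearest and sits beyond the scatter above it. For the measured compounds named here, the one measured step, an at least 100-fold lower number from compound 1 to compound 3 (2.00 log units; beyond the scatter), concerns the carbonyl substituent and does not touch the aryl ring.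

Compound 4 `O=C([C@@H]1CC2CCC1C2)N1CC(c2nc(-c3cccc(F)c3)no2)C1` differs from compound 3 by fluoro in place of chloro on an aromatic carbon. Going by the values given here, no measured step covers this change alone: compound 1 and compound 2 differ at the ring and also on the carbonyl substituent, so their values only hint that the fluorophenyl is tolerated. The expected step is a 1.5-fold higher number from compound 3 to compound 4 (0.18 log units; within the scatter), within the scatter. Compound 4 is estimated at 150 nM, with a range from 50 nM to 600 nM.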

Compound 4, half-maximal effective concentration: 100 nM
Compound 4: middle estimate off by 1.5-fold (0.18 log units), on the high side, within the range that was stated.
By their numbers in this assay, from the lowest: compounds 3 and 4 (each within the scatter of the next); then compound 2. At a limit, above all of these: compound 1.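

With the carbonyl substituent of compound 3 held fixed, 3-chlorophenyl and 3-fluorophenyl cannot be told apart in this assay (a 1.0-fold higher number from compound 3 to compound 4 (0.01 log units; within the scatter)). The carbonyl change also now has a measured size on the 3-fluorophenyl side (a 24-fold lower number from compound 2 to compound 4 (1.38 log units; beyond the scatter)). The earlier step for that change starts from compound 1, whose entry is a limit of the assay and not a number: the limit of > 10000 nM in this assay, at which 1 of the 4 values shown sits.

From the compounds shown here alone, how this aromatic carbon responds to a methoxy, a nitrile or plain hydrogen in place of chloro or fluoro remains open. So does whether a simple cyclohexyl on the carbonyl would match the present group.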